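A few compounds are considered here, and "the series" means these few. Any claim that something is new, unique, unknown or untested is made for them only; others in the source may bear on it.

Three compounds were measured in a toxicity assay on the whole organism (J774 cells) for cytotoxicity, with Mus musculus as the target, read by MTT assay, with a stated time of 24 h, tested at 30 uM; on this read-out higher numbers stand for a weaker effect at the one concentration tested and lower numbers for a stronger effect:

Compound 1 `CCCCCCCCCO[C@@H]1[C@@H](N)[C@@H](O[C@H]2[C@H](O)[C@@H](OCCCCCCCCC)[C@H](N)C[C@@H]2N)O[C@H](CN)[C@H]1O` gives 38.8%.
Compound 2 `CCCCCCCCCO[C@@H]1[C@@H](N)[C@@H](OCC(O)CNCCCO)O[C@H](CN)[C@H]1OCCCCCCCCC` gives 13.7%.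
Compound 3 `NC[C@H]1O[C@H](O[C@H]2[C@H](OCCCc3ccc4ccccc4c3)[C@@H](O)[C@H](N)C[C@@H]2N)[C@H](N)[C@@H](OCCCc2ccc3ccccc3c2)[C@@H]1O` gives 89.5%.

Compound 2 stands lowest of these three numbers. Its nearest neighbour is compound 1, whose number lies higher by a margin beyond the scatter, and its furthest is compound 3, whose number lies higher by a much larger margin, also beyond the scatter.

Compound 4 `CCCCCCCCCO[C@@H]1[C@@H](N)[C@@H](OC[C@H](O)CN)O[C@H](CN)[C@H]1OCCCCCCCCC` has not been measured. It differs from compound 2 by 2-amino-1-hydroxyethyl in place of 1-hydroxy-2-((3-hydroxypropyl)amino)ethyl on a saturated chain carbon bound to an oxygen on a saturated carbon. Among the measured compounds shown here, no step between measured compounds isolates this change, so the expectation rests on compound 2 alone. A small step is expected, if anything toward a higher number, and it may well lie within the scatter. Compound 4 is therefore estimated at 20%, between 5% and 45%, which means an expected step of a number 6.3 percentage points higher from compound 2 to compound 4 (within the scatter).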

Compound 4, a percentage reported as activity, at one concentration (the size of the read-out at that concentration, not a potency): 14.4%
Estimate against measurement, compound 4: 5.6 percentage points above; the measured number falls inside the stated range.
By their numbers in this assay, from the lowest: compounds 2 and 4 (each within the scatter of the next); then compound 1; then compound 3.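

At this place, on a saturated chain carbon bound to an oxygen on a saturated carbon, putting 2-amino-1-hydroxyethyl in place of 1-hydroxy-2-((3-hydroxypropyl)amino)ethyl reads in this assay as a number 0.7 percentage points higher from compound 2 to compound 4 (within the scatter). Among the compounds shown here, this is the first pair that isolates a single change, and on this read-out the shorter group and the longer one cannot be told apart. No measurement shown here accounts for this result. The compounds shown leave open how a carboxylic acid or a dimethylamino group at this place would read.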